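From methoxy to sec-butoxy on compound 3

This account rests on a few compounds, and the source may have more. Where it says the series, first, only, none or still open, it means among the compounds named here.

Of the compounds shown here, three have been read so far in an ADME assay on RAW264.7 cells (Mus musculus) for cytotoxicity, read by MTT assay, with a stated time of 24 h, in the absence of a further agent (on this read-out higher numbers stand for weaker inhibition and lower numbers for stronger inhibition), and none of them gives a number. Compound 1 `O=C1OC(Cc2nc(Cc3ccccc3)no2)c2ccccc21` gives > 40000 nM as a limit of the assay. Compound 2 `O=C1OC(Cc2nc(-c3ccc(Oc4ccccc4)cc3)no2)c2ccccc21` gives > 40000 nM as a limit of the assay too. Compound 3 `COc1ccc(C(O)C2OC(=O)c3c(OC)cc(OC)cc32)cc1` gives > 40000 nM as a limit of the assay as well. Compound 3 thus stands together with the other two (the limit of > 40000 nM in this assay, at which 3 of the 3 values shown sit) and no order among the three can be read.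

Compound 4 `CCC(C)Oc1ccc(C(O)C2OC(=O)c3c(OC)cc(OC)cc32)cc1` has not yet been measured. It differs from compound 3 in one place, with sec-butyl in place of methyl on an oxygen on an aromatic ring so that methoxy becomes sec-butoxy. Within the data shown here, no pair of measured compounds differs in one place, so the series offers no measured step to go by. The step of a number no higher from compound 3 to compound 4 (the limit leaves the size open) is expected to stay within the usual scatter, with no direction favoured. This expectation rests only on compound 3 and the two others sharing its position (the limit of > 40000 nM in this assay, at which 3 of the 3 values shown sit) and remains weakly supported. Compound 4 is estimated at 40000 nM with an expected range from 18000 nM to 80000 nM and another report as a limit is the likeliest outcome.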

Compound 4, half-maximal inhibitory concentration: > 40000 nM
Compound 4: only a limit was reported; the forecaster's own chance of this, stated with the estimate: 75%; the middle value lies on the limit itself.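

Among these compounds, compound 3 and compound 4 both stand at a limit of the assay, so no step between them can be read: the limit of > 40000 nM in this assay, at which 4 of the 4 values shown sit. The compounds shown leave open how methoxy and sec-butoxy compare on the shared core, and whether any compound in the series gives an actual number in this assay.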